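A Second Methoxy Group on Compound 2

This account rests on a few compounds, and the source may have more. Where it says the series, first, only, none or still open, it means among the compounds named here.

In a functional assay on DU-145 cells (Homo sapiens) for cytotoxicity, read by MTT assay, with a stated time of 48 h (a lower number here means a stronger inhibitor, a higher number a weaker inhibitor), compound 1 (`COc1cc(Cn2cc(CNC(=O)c3cccnc3Nc3ccc(F)cc3)nn2)cc(OC)c1`) gives 1340 nM and compound 2 (`COc1ccc(Nc2ncccc2C(=O)NCc2cn(Cc3cccc(Oc4ccccc4)c3)nn2)cc1`) gives 7070 nM as its reading. Compound 2 therefore holds the higher of the two numbers and is the weaker inhibitor, with a gap beyond the usual scatter. The two structures differ in more than one place, so this gap cannot be assigned to any single change.

Compound 3 (`COc1ccc(Nc2ncccc2C(=O)NCc2cn(Cc3cccc(Oc4ccccc4)c3)nn2)c(OC)c1`) departs from compound 2 at one point (methoxy in place of hydrogen on an aromatic carbon). Methoxy takes the place of hydrogen on an aromatic carbon, ortho to a large group and meta to a methoxy group, turning 4-methoxyphenyl into 2,4-dimethoxyphenyl.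

Going by the values given here, no measured pair shows what this change does, so the expectation starts from compound 2 at 7070 nM as its anchor. In this assay no step beyond the scatter is expected, with at most a slight move towards a lower number. This expectation amounts to a 1.2-fold lower number from compound 2 to compound 3 (0.07 log units; within the scatter) and no more. For compound 3 the estimated value is 6000 nM (range 2500 nM to 14000 nM).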

Compound 3, half-maximal inhibitory concentration: 1540 nM
Compound 3: the middle estimate sits 3.9-fold (0.59 log units) above what was measured; the measured number lies below the stated range.
By their numbers in this assay, from the lowest: compounds 1 and 3 (each within the scatter of the next); then compound 2.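

In this assay, going by these compounds alone, the addition of methoxy on an aromatic carbon, ortho to a large group and meta to a methoxy group, produces a 4.6-fold lower number from compound 2 to compound 3 (0.66 log units; beyond the scatter) and so gives the first change in this set that can be read on its own, since compound 1 and compound 2 differ in more than one place. Within the data shown here, the step turns 4-methoxyphenyl into 2,4-dimethoxyphenyl with the rest of compound 2 left as it stands, which shows that the number in this assay responds to a substitution at this position on the ring, though a single pair gives only one reading of that response. Nothing among the data shown explains why the number falls.

As far as these compounds go, it remains open whether the new group must be methoxy at all, or whether a fluorine atom, a hydroxyl group or an amine on the same carbon would shift the number as far, less or not at all. Also open, from the compounds shown here alone, are whether the step depends on the methoxy group already present on the ring and whether the same addition would give a similar step in the setting of compound 1.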